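A Methyl Added to a Weak Fused-Ring Inhibitor

The compounds below may be only part of what the source reports. "The series", "measured", "known", "first", "only" and "open" are said of these compounds alone.

compound 1, `CCCc1nc(C)c2c(CC)nnc(SC)n12`: > 48000 nM
compound 2, `CCOC(=O)CSc1nncc2cnc(C)n12`: 52000 nM

Going by the values given here, in a functional assay for inhibition, with Homo sapiens as the target (a higher number here means a weaker inhibitor, a lower number a stronger inhibitor), compound 2 gives 52000 nM, the only true number among the two results. For compound 1 the assay reports only a limit, > 48000 nM (the limit of > 48000 nM in this assay, at which 1 of the 2 values shown sits). Compound 3, `CCOC(=O)CSc1nncc2c(C)nc(C)n12`, differs from compound 2 by methyl in place of hydrogen on an aromatic carbon. Among the compounds with values here, no step between measured compounds is available, so the size of such a change is unknown here; a step no larger than the usual scatter, in either direction, is expected. Compound 3 is expected to give 50000 nM, between 20000 nM and 120000 nM. The expected step is a 1.0-fold lower number from compound 2 to compound 3 (0.02 log units; within the scatter).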

Compound 3, half-maximal inhibitory concentration: > 48000 nM
Compound 3 was reported as a limit; the forecaster's own chance of this, stated with the estimate: 40%; the middle value is on the limit's open side.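

In this assay, going by these compounds alone, compound 3 gives > 48000 nM, a limit and not a number, and no step from compound 2 to compound 3 can be read. The compounds shown leave open how far methyl in place of hydrogen on an aromatic carbon moves the result.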